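Swapping Methoxy for a Carbamoyl Chain on Compound 1

A few compounds are considered here, and "the series" means these few. Any claim that something is new, unique, unknown or untested is made for them only; others in the source may bear on it.

Among the compounds with values here, in an in vivo ADME assay on the whole organism for pharmacokinetics, with Rattus norvegicus as the target, at a dose of 2 mg/kg by the oral route (a lower number here means less compound in the circulation, a higher number more compound in the circulation at the dose given), compound 1 `COc1ccc2c(c1)CC(c1nc3ccc(-c4ccnc(N)n4)cc3[nH]1)CO2` gives 900 nM, the higher of only two numbers. Compound 2 `Nc1nccc(-c2ccc3nc(C4COc5c(cccc5C(=O)NC5CC5)C4)[nH]c3c2)n1` gives 9 nM, a gap well beyond the scatter. Compound 3 `CN(C)CCCNC(=O)c1ccc2c(c1)CC(c1nc3ccc(-c4ccnc(N)n4)cc3[nH]1)CO2` keeps the core of compound 1 but carries (3-(dimethylamino)propyl)carbamoyl in place of methoxy on an aromatic carbon. Within the data shown here, no measured step isolates this change, so the expectation is tentative: a downward step in this assay, beyond the scatter, with compound 2 at 9 nM as the only lower reference. The estimated step is a 15-fold lower number from compound 1 to compound 3 (1.18 log units; beyond the scatter). For compound 3, the expected value is 60 nM, within an estimated range of 10 nM to 300 nM.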

Compound 3, maximal plasma concentration: 3 nM
Compound 3: the middle estimate sits 20-fold (1.30 log units) above what was measured, and the stated range ends above it.
By their numbers in this assay, from the lowest: compound 3; then compound 2; then compound 1.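

Within the data shown here, at this position, on an aromatic carbon meta to a fused ring and para to a fused ring, this assay responds strongly to the change: (3-(dimethylamino)propyl)carbamoyl in place of methoxy gives a 300-fold lower number from compound 1 to compound 3 (2.48 log units; beyond the scatter) as the only measured step here. It shows that this place on the core of compound 1 is not indifferent to what it carries, and that this exchange leaves much less compound in the circulation at the dose given. Nothing measured here bears on why the number falls so far.

Going by these compounds, whether the fall follows the carbamoyl link or the dimethylamino end of the chain remains open. A primary amide, a carboxylic acid or a shorter chain on this carbon would help tell these apart.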